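The source may hold more compounds than are shown below. What is called first, only, known or untested is meant among the compounds shown, and "the series" means these compounds.

Of the compounds shown here, two built on one shared core have so far been tested in an ADME assay on MT4 cells (Homo sapiens) for cytotoxicity, read by MTT assay, with a stated time of 5 days; on this read-out higher numbers stand for lower toxicity in this test and lower numbers for higher toxicity in this test. In this test, compound 1 `COCCNc1cc(Oc2c(C)cc(/C=C/C#N)cc2C)nc(Nc2ccc(C#N)cc2)n1` gives 3190 nM and compound 2 `Cc1cc(/C=C/C#N)cc(C)c1Oc1cc(NC2CC2)nc(Nc2ccc(C#N)cc2)n1` gives 3000 nM. With only these two numbers available, compound 2 stands level with compound 1 within the usual scatter.

Compound 3 `Cc1cc(/C=C/C#N)cc(C)c1Oc1cc(NCCN2CCNCC2)nc(Nc2ccc(C#N)cc2)n1` keeps the core of compound 2 and changes one group: 2-(piperazin-1-yl)ethyl in place of cyclopropyl on a nitrogen on an aromatic ring. Among the compounds with values here, only one measured step bears on this change. Cyclopropyl in place of 2-methoxyethyl on that same nitrogen gave a 1.1-fold lower number from compound 1 to compound 2 (0.03 log units; within the scatter). That step is small, so swapping one of these two groups for the other left the number in this assay effectively unmoved. Neither group contains a piperazine ring, however, which makes this thin evidence for compound 3. No change beyond the scatter is therefore expected, and no direction can be favoured. The estimated step is a 1.3-fold higher number from compound 2 to compound 3 (0.12 log units; within the scatter). For compound 3, the expected value is 4000 nM, with an estimated range of 1500 nM to 15000 nM.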

Compound 3, half-maximal cytotoxic concentration: 3650 nM
For compound 3 the middle estimate is 1.1-fold (0.04 log units) above the measured one; measured number inside the range.
By their numbers in this assay, from the lowest: compounds 2, 1 and 3 (each within the scatter of the next).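

In this assay, putting 2-(piperazin-1-yl)ethyl in place of cyclopropyl on the nitrogen gives a 1.2-fold higher number from compound 2 to compound 3 (0.09 log units; within the scatter), and piperazin-1-yl in place of methoxy on the chain gives a 1.1-fold higher number from compound 1 to compound 3 (0.06 log units; within the scatter). The earlier pair showed only that cyclopropyl and 2-methoxyethyl read alike here, whereas this result extends that to a far larger group of 8 heavy atoms, with a six-membered non-aromatic ring holding 2 hetero atoms and with 1 hydrogen-bond donor, so this position has now held three quite different groups with all the numbers level in this test. Nothing available offers a reason for this flat result.

The compounds shown leave open whether the number stays level with a group of another kind on this nitrogen, such as a carboxylic acid at the end of a two-carbon chain, a simple dimethylamino group on that chain, or a longer chain carrying the same piperazine ring. They also leave open whether a change elsewhere on the shared core would move the number beyond the usual scatter, since all three compounds differ only at this one nitrogen.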